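The compounds below may be only part of what the source reports. "The series", "measured", "known", "first", "only" and "open" are said of these compounds alone.

Working notes on the series. Compound 1 `CCCCNc1nc(N)nc(C)c1CCCc1ccccc1` gives 749 nM in an assay on HEK293 cells for agonist activity at Toll-like receptor 8 (Homo sapiens), read by spectrophotometry; on this read-out lower numbers stand for an effect already at smaller amounts and higher numbers for an effect only at larger amounts of compound. Compound 2 `CCCCNc1nc(N)nc(C)c1CCCn1c(C)nc2ccccc21` gives 366 nM in this assay. Compound 3 `CCCCNc1nc(N)nc(C)c1CCCCc1ccccc1` gives 857 nM in this assay, the highest of the three numbers; its gap to compound 1 is within the scatter, its gap to compound 2 lies beyond it. For the measured compounds named here, the only single-point step so far, a 1.1-fold higher number from compound 1 to compound 3 (0.06 log units; within the scatter), shows that benzyl in place of phenyl hardly moves the number. Compound 4 `CCCCNc1nc(N)nc(C)c1CCCN1CCN(C)CC1` differs from compound 3 by 4-methylpiperazin-1-yl in place of benzyl on a saturated chain carbon, three bonds along the chain from an aromatic carbon. Going by the values given here, no measured step exchanges an aromatic ring on the chain for a non-aromatic ring with hetero atoms, so no direct guide exists. The step to compound 4 is therefore expected to stay within the scatter, direction open, a 1.1-fold higher number from compound 3 to compound 4 (0.02 log units; within the scatter). Compound 4 is estimated at 900 nM, range 300 nM to 3000 nM.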

Compound 4, half-maximal effective concentration: 179 nM
For compound 4 the middle estimate is 5.0-fold (0.70 log units) above the measured one; measured number outside the range, below it.
By their numbers in this assay, from the lowest: compound 4; then compound 2; then compounds 1 and 3 (each within the scatter of the next).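

At this position, on a saturated chain carbon, three bonds along the chain from an aromatic carbon, the number does respond to the group: 4-methylpiperazin-1-yl in place of benzyl gives a 4.8-fold lower number from compound 3 to compound 4 (0.68 log units; beyond the scatter) and in place of phenyl gives a 4.2-fold lower number from compound 1 to compound 4 (0.62 log units; beyond the scatter) while benzyl in place of phenyl stayed within the scatter. An aromatic ring at this place is therefore not required for a low number in this assay since compound 4 carries a six-membered non-aromatic ring with 2 hetero atoms instead. Nothing at hand accounts for the size of these steps.
Open, as far as these compounds go, is whether the ring itself or its nitrogens and methyl carry the step. Morpholine, piperidine, an open-chain dimethylamino group or a longer chain ahead of the 4-methylpiperazin-1-yl would separate these.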